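Swapping the side group on the core: acid dissociation

This account rests on a few compounds, and the source may have more. Where it says the series, first, only, none or still open, it means among the compounds named here.

The shared core of compound 1 `c1ccc(CCc2ccc3c(NCCCNCc4ccco4)ccnc3c2)cc1` carries a chain with an amine and a furan, and on one aromatic carbon a phenethyl group. In a physicochemical assay for acid dissociation, compound 1 gives 9.47. Two companions keep the core and the amine chain but vary elsewhere: compound 2 `COc1cccc(CNCCCNc2ccnc3cc(CCC(C)C)ccc23)c1O` gives 9.47, and compound 3 `COc1cccc(CNCCCNc2ccnc3cc(Cc4ccc(C#N)cc4)ccc23)c1O` gives 9.47. Compound 1 therefore stands level with both, within the scatter of this assay, and nothing among the three sets it apart.

Compound 4 `COc1ccc(Oc2ccc3c(NCCCNCc4ccco4)ccnc3c2)cc1` is the next case. Relative to compound 1 the change is 4-methoxyphenoxy in place of phenethyl on an aromatic carbon. The only measured step that speaks to such a swap is the one between compound 2 and compound 3, where a change in the group that varies among these compounds gave no change at the digits printed from compound 2 to compound 3 (within the scatter). That step left the acid dissociation constant untouched, and the amine chain that the measurement most plausibly reports on is unchanged in compound 4. The expectation is therefore a step of a number 0.02 log units lower from compound 1 to compound 4 (within the scatter), which is no change beyond the scatter. Compound 4 is estimated at 9.45, with a range from 9.1 to 9.8.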

Compound 4, acid dissociation constant: 9.28
Estimate against measurement, compound 4: 0.17 log units above; low and high end bracket the measured number.
By their numbers in this assay, from the lowest: compounds 4, 1, 2 and 3 (each within the scatter of the next).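

In this assay, the swap of phenethyl for 4-methoxyphenoxy on an aromatic carbon of the shared core reads as a number 0.19 log units lower from compound 1 to compound 4 (within the scatter) and stays within the usual scatter of the measurement. The earlier step concerned a group on a saturated chain carbon and a different amine chain, whereas this pair keeps the furan-bearing amine chain fixed and alters only the group on the aromatic carbon, so the reading can be tied to this one place. The group that enters has 2 hydrogen-bond acceptors and the group that leaves has 0 hydrogen-bond acceptors, yet the two compounds cannot be told apart in this measurement, and nothing shown here bears on why that is so.

Going by these compounds, both groups compared at this place contain a six-membered aromatic ring of carbon only, so it remains open how the reading would respond to a group of another kind there, such as an amine, a carboxylic acid or a plain longer carbon chain. On these data alone, whether the same swap would read alike on the amine chain of compound 2 also remains open.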